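The compounds below may be only part of what the source reports. "The series", "measured", "known", "first", "only" and "open" are said of these compounds alone.

Working notes on the series. All three measured compounds share one core and differ only in the group on the aromatic ring. Compound 1 `COC(=O)C1=C(C)N=C(C)/C(=C(\O)OC)C1c1cccc(OC(C)=O)c1` gives 6030 nM in a functional assay (muscle tissue) with Cavia porcellus as the target; a lower number here means that less compound is needed, a higher number that more compound is needed for the effect. Compound 2 `COC(=O)C1=C(C)N=C(C)/C(=C(\O)OC)C1c1cccc(I)c1` gives 41.7 nM, and compound 3 `COC(=O)C1=C(C)N=C(C)/C(=C(\O)OC)C1c1cccc(OC)c1` gives 191 nM, which leaves compound 3 second highest of the three numbers, nearer to compound 2 than to compound 1. The measured steps run a 140-fold lower number from compound 1 to compound 2 (2.16 log units; beyond the scatter), a 32-fold lower number from compound 1 to compound 3 (1.50 log units; beyond the scatter) and a 4.6-fold higher number from compound 2 to compound 3 (0.66 log units; beyond the scatter).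

Compound 4 `COC(=O)C1=C(C)N=C(C)/C(=C(\O)OC)C1c1cccc(C(F)(F)F)c1` differs from compound 3 by trifluoromethyl in place of methoxy on an aromatic carbon. Within the data shown here, no measured step puts a trifluoromethyl group in place, so there is no direct precedent. Among the measured compounds shown here, the nearest guide is a 4.6-fold higher number from compound 2 to compound 3 (0.66 log units; beyond the scatter), which shows that the methoxy on that position gave a higher number than iodo; both exchanges at this position so far were beyond the scatter, the removal of methoxy here is therefore expected to move the number too, most plausibly downward and by a modest step, with wide uncertainty. Compound 4 is expected at 70 nM, between 20 nM and 250 nM. That estimate means a step of a 2.7-fold lower number from compound 3 to compound 4 (0.44 log units; beyond the scatter).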

Compound 4, half-maximal effective concentration: 74.1 nM
For compound 4 the middle estimate is 1.1-fold (0.02 log units) below the measured one; low and high end bracket the measured number.
By their numbers in this assay, from the lowest: compounds 2 and 4 (each within the scatter of the next); then compound 3; then compound 1.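

In this assay, the exchange of methoxy for trifluoromethyl gives a 2.6-fold lower number from compound 3 to compound 4 (0.41 log units; beyond the scatter), while the exchange of iodo for trifluoromethyl gives a 1.8-fold higher number from compound 2 to compound 4 (0.25 log units; within the scatter), so trifluoromethyl and iodo cannot be told apart on this aromatic carbon. With an 81-fold lower number from compound 1 to compound 4 (1.91 log units; beyond the scatter) added, the two groups without oxygen, iodo and trifluoromethyl, both stand at lower numbers than the two with oxygen, methoxy and acetoxy, and none of the four compounds goes against this. Nothing available explains this ordering.

On these data alone, whether oxygen itself is what separates these groups stays open, and an amine or a carboxylic acid on the same aromatic carbon would test that reading. The compounds shown also leave open how a longer chain, such as ethoxy, would behave there.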